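The source may hold more compounds than are shown below. What is called first, only, known or untested is meant among the compounds shown, and "the series" means these compounds.

Working notes, one series

The series shares one core, a chloropurine bearing a cyclopropyl-substituted glycinamide, and varies the amino-acid part on the amide. Compound 1 `O=C(CN(c1nc(Cl)nc2[nH]cnc12)C1CC1)N[C@@H](CO)C(=O)OCc1ccccc1` carries a serine benzyl ester; compound 2 `C[C@H](NC(=O)CN(c1nc(Cl)nc2[nH]cnc12)C1CC1)C(=O)OCc1ccccc1` an alanine benzyl ester; compound 3 `O=C(CN(c1nc(Cl)nc2[nH]cnc12)C1CC1)N[C@@H](CC(=O)OCc1ccccc1)C(=O)OCc1ccccc1` an aspartate dibenzyl ester. In a functional assay on the whole organism (Tail, strain ICR) with Mus musculus as the target, in the tail flick test, with a stated time of 120 min, at a dose of 25 umol/kg by the oral route (on this read-out higher numbers stand for a stronger effect at the one dose given and lower numbers for a weaker effect), compound 1 gives 34.5%, compound 2 gives 36.1% and compound 3 gives 12.1%. Compound 1 thus stands second highest of the three numbers, with compound 2 nearest a number 1.6 percentage points higher from compound 1 to compound 2 (within the scatter) and compound 3 furthest a number 22.4 percentage points lower from compound 1 to compound 3 (beyond the scatter); the same direction is seen a number 24 percentage points lower from compound 2 to compound 3 (beyond the scatter).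

Compound 4 `O=C(CN(c1nc(Cl)nc2[nH]cnc12)C1CC1)N[C@@H](CO)C(=O)O` differs from compound 1 by hydrogen in place of benzyl on an oxygen next to a carbonyl group, leaving a carboxy in place of the benzyloxycarbonyl. Among the measured compounds shown here, none of the measured steps alters this ester; all three change the saturated chain carbon of the amino-acid part. The only pointer is that adding a benzyloxycarbonyl to that chain lowers the read-out a number 22.4 percentage points lower from compound 1 to compound 3 (beyond the scatter), whereas the hydroxy and hydrogen pair is within scatter. For the measured compounds named here, no step shows what removal of the ester benzyl does, so the expectation is weakly founded. Compound 4 is expected to fall somewhat, a number 10.5 percentage points lower from compound 1 to compound 4 (beyond the scatter), with a wide range. The estimate for compound 4 is 24%, between 6% and 45%.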

Compound 4, a percentage reported as activity, at one dose (the size of the read-out at that dose, not a potency): 39%
Estimate against measurement, compound 4: 15 percentage points below, within the range that was stated.
By their numbers in this assay, from the lowest: compound 3; then compounds 1, 2 and 4 (each within the scatter of the next).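

Among the compounds shown here, the ester position is read here for the first time: in this assay, hydrogen in place of benzyl on an oxygen next to a carbonyl group gives a number 4.5 percentage points higher from compound 1 to compound 4 (within the scatter) and so the benzyl, with its six-membered aromatic ring of carbon only, is not required for the read-out of this serine compound at the one dose given. Benzyloxycarbonyl to carboxy at this place therefore contrasts with the chain carbon, where benzyloxycarbonyl in place of hydroxy gives a number 22.4 percentage points lower from compound 1 to compound 3 (beyond the scatter) and moves the number beyond the scatter. Nothing at hand explains why removing the ester benzyl leaves the number within the scatter of compound 1.

From the compounds shown here alone, it remains open whether the same exchange gives a comparable result on compound 2 or compound 3, where a carboxylic acid would replace one or both benzyl esters on a different amino-acid part. Also open, going by these compounds, is how a methyl ester or a primary amide at this place would read compared with the benzyl ester of compound 1 and the carboxy of compound 4.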